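The compounds below may be only part of what the source reports. "The series", "measured", "known", "first", "only" and "open" are said of these compounds alone.

Three compounds have so far been measured in a functional assay on MCF7 cells (Homo sapiens) for antiproliferative activity, read by MTT assay, with a stated time of 72 h; a lower number here means a stronger inhibitor, a higher number a weaker inhibitor:

compound 1 `O=C(N/N=C/c1cccc(Br)c1)Nc1ccc(Oc2ccnc3[nH]ccc23)c(F)c1` gives 49 nM;
compound 2 `O=C(N/N=C/c1ccc(F)cc1Cl)Nc1ccc(Oc2ccnc3[nH]ccc23)c(F)c1` gives 7610 nM;
compound 3 `O=C(N/N=C/c1ccc(O)c(Br)c1)Nc1ccc(Oc2ccnc3[nH]ccc23)c(F)c1` gives 8230 nM.

Compound 1 has the lowest number of the three in this assay; compound 2 is nearest to it and compound 3 furthest, and both lie well beyond the scatter from it. The next compound, compound 4 `O=C(N/N=C/c1cc(Br)c(O)c(Br)c1)Nc1ccc(Oc2ccnc3[nH]ccc23)c(F)c1`, differs from compound 1 in one place: 3,5-dibromo-4-hydroxyphenyl in place of 3-bromophenyl on a carbon with a double bond to nitrogen. Going by the values given here, two measured steps bear on this change. Putting hydroxy in place of hydrogen on an aromatic carbon of compound 1 gave a 170-fold higher number from compound 1 to compound 3 (2.23 log units; beyond the scatter), and exchanging the whole aryl group gave a 160-fold higher number from compound 1 to compound 2 (2.19 log units; beyond the scatter), while the two weaker compounds differ from each other by only a 1.1-fold higher number from compound 2 to compound 3 (0.03 log units; within the scatter). Among the compounds with values here, compound 4 carries the same hydroxy as compound 3 together with a second bromine, so the step to compound 3 is the closer precedent; the second bromine has no measured precedent here. The step is therefore expected to be large and toward a higher number, roughly a 120-fold higher number from compound 1 to compound 4 (2.09 log units; beyond the scatter). Compound 4 is estimated at 6000 nM, with a likely range of 1200 nM to 30000 nM.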

Compound 4, half-maximal inhibitory concentration: "not active" (no number reported)
The entry for compound 4 holds no number; no gap can be computed for the estimate.
By their numbers in this assay, from the lowest: compound 1; then compounds 2 and 3 (each within the scatter of the next).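

In this assay, going by these compounds alone, compound 4 is reported only as "not active", without a number, so no step between compound 4 and compounds 1, 2 or 3 can be read. Nothing available explains this result. The compounds shown leave open how far compound 4 lies from compound 1 and what the second bromine alone contributes.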